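The source may report more compounds than this note shows. Statements on the series, on what has been measured and on what is new or still open speak of the compounds shown alone.

Compound 1 `C[C@@H]1CN(C(=O)[C@@H]2C[C@H](S(=O)(=O)c3ccccc3)C[C@H]2C(=O)NC2(C#N)CC2)C[C@H](C)O1` is the stronger of the two measured compounds here: in a functional assay on A20 cells (Mus musculus) for inhibition, with stated times of 1 h, 16 h and 24 h (on this read-out higher numbers stand for weaker inhibition and lower numbers for stronger inhibition), compound 1 gives 1 nM, the lowest number measured. Among the measured compounds shown here, its only measured neighbour, compound 2 `N#CC1(NC(=O)[C@@H]2C[C@@H](S(=O)(=O)c3ccccc3)C[C@H]2C(=O)N2CCS(=O)(=O)CC2)CC1`, differs from it solely in the group attached to one carbonyl carbon, and in this assay compound 2 gives 816 nM. That single exchange produced an 820-fold higher number from compound 1 to compound 2 (2.91 log units; beyond the scatter), showing that this position is very sensitive to what is placed on it.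

Compound 3 `CN(C)C(=O)[C@@H]1C[C@H](S(=O)(=O)c2ccccc2)C[C@H]1C(=O)NC1(C#N)CC1` changes the same position in another way: dimethylamino in place of 2,6-dimethylmorpholin-4-yl on a carbonyl carbon. For the measured compounds named here, the step from compound 1 to compound 2 is the only measured guide, and it bears directly on this position, but it replaced one six-membered ring with another; here the ring is lost altogether and a much smaller group enters. Going by the values given here, no measured pair shows what such a shrinking does. Given the large loss seen at this position, a weakening beyond the scatter is expected, though smaller than the one seen with compound 2: compound 3 is expected to show a 30-fold higher number from compound 1 to compound 3 (1.48 log units; beyond the scatter). The estimated value for compound 3 in this assay is 30 nM, within a range from 4 nM to 300 nM.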

Compound 3, half-maximal inhibitory concentration: 91 nM
The estimate for compound 3 lay 3.0-fold (0.48 log units) below the measured number; measured number inside the range.
By their numbers in this assay, from the lowest: compound 1; then compound 3; then compound 2.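

In this assay the ring-free dimethylamino group costs a great deal against 2,6-dimethylmorpholin-4-yl on this carbonyl carbon (a 91-fold higher number from compound 1 to compound 3 (1.96 log units; beyond the scatter)), yet it keeps far more inhibition than the earlier exchange alone might suggest. Set against 1,1-dioxothiomorpholin-4-yl, the same small group does better (a 9.0-fold lower number from compound 2 to compound 3 (0.95 log units; beyond the scatter)), so having a six-membered ring at this position does not by itself decide the outcome: one such ring ranks above dimethylamino and the other ranks below it. Nothing available here accounts for this order.

The compounds shown leave open which part of 2,6-dimethylmorpholin-4-yl matters, the ring, its oxygen or its two methyl groups, and a plain morpholin-4-yl or a piperidin-1-yl on the same carbonyl carbon would help to separate these. They also leave open whether a longer open chain, such as diethylamino, would fall closer to compound 1 or to compound 3.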